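Swapping the Dimethoxybenzyl Arm for a Fluorobenzyl Arm

The source may report more compounds than this note shows. Statements on the series, on what has been measured and on what is new or still open speak of the compounds shown alone.

Compound 1 `COc1ccc(CNc2nc3cc(N)cc(N)c3nc2-c2ccccc2)cc1OC` is known in a functional assay on HT-29 cells (Homo sapiens) for inhibition, read by sulforhodamine B assay, with a stated time of 48 h (a lower number here means that less compound is tolerated, a higher number that more compound is tolerated), only through a limit: compound 1 gives < 100000 nM, which is a limit of the assay and not a number. Among the measured compounds shown here, its single measured neighbour is compound 2 `COc1cc(CNc2nc3cc(N)cc(N)c3nc2-c2ccccc2)cc(OC)c1OC`, carrying methoxy in place of hydrogen on an aromatic carbon; in this assay compound 2 gives 43700 nM. The step that the limit leaves unreadable from compound 1 to compound 2 cannot be read because of the limit of < 100000 nM in this assay, at which 1 of the 2 values shown sits. Compound 3 `Nc1cc(N)c2nc(-c3ccccc3)c(NCc3ccc(F)cc3)nc2c1` alters compound 1 at a different point: 4-fluorophenyl in place of 3,4-dimethoxyphenyl on a saturated chain carbon bound to a nitrogen on an aromatic ring. For the measured compounds named here, no measured step touches this exchange, and the only step that exists is unreadable, so the data give no size and no direction for it beyond the scatter. Compound 3 is therefore expected to give an estimated 45000 nM, somewhere between 12000 nM and 100000 nM. The step that the limit leaves unreadable from compound 1 to compound 3 is expected to stay small or to remain unreadable.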

Compound 3, concentration lethal to 50% of the cells: < 100000 nM
Compound 3 ended at the assay's limit; the forecaster's own chance of this, stated with the estimate: 35%; the middle value does not contradict the limit.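

Among the compounds shown here, compound 1 and compound 3 both stand at a limit of this assay and not at a number, so no new step between them can be read: the limit of < 100000 nM in this assay, at which 2 of the 3 values shown sit. From the compounds shown here alone, whether 4-fluorophenyl in place of 3,4-dimethoxyphenyl changes the result at all, and in which direction, stays open.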